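A Longer Chain on Compound 3

The source may report more compounds than this note shows. Statements on the series, on what has been measured and on what is new or still open speak of the compounds shown alone.

In an ADME assay on Vero cells (Chlorocebus sabaeus) for cytotoxicity, read by reporter gene assay, with a stated time of 4 days (a lower number here means a stronger inhibitor, a higher number a weaker inhibitor), compound 1 `CCCC(C)C(=O)NCC(C)(C)CC1=C(O)C(=O)c2ccccc2C1=O` gives 48100 nM, compound 2 `CCCC(C)C(=O)OCC(C)(C)CC1=C(O)C(=O)c2ccccc2C1=O` gives 120 nM, and compound 3 `CCCCCCCCC(=O)OCC(C)(C)CC1=C(O)C(=O)c2ccccc2C1=O` gives 150000 nM, the highest of the three numbers. Compound 4 `CCCCCCCCCCCCCCCCCC(=O)OCC(C)(C)CC1=C(O)C(=O)c2ccccc2C1=O` has not yet been measured. It differs from compound 3 by nonyl in place of hydrogen on a saturated chain carbon, eight bonds along the chain from a carbonyl carbon, on a saturated chain carbon, eight bonds along the chain from a carbonyl carbon.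

One measured step changes a group in this same chain: a 1300-fold higher number from compound 2 to compound 3 (3.10 log units; beyond the scatter), with octyl in place of 1-methylbutyl on a carbonyl carbon. That step was large. The other step, a 400-fold lower number from compound 1 to compound 2 (2.60 log units; beyond the scatter), concerns a different place and offers little guidance. Within the data shown here, no measured pair shows what further lengthening of a chain like that of compound 3 does, so a repeat of the large rise is not assumed. The expected change is a 1.3-fold higher number from compound 3 to compound 4 (0.12 log units; within the scatter), which means no step beyond the scatter is expected. For compound 4 the estimated value is 200000 nM, within an expected range of 50000 nM to 600000 nM.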

Compound 4, half-maximal inhibitory concentration: 15500 nM
Beside the measured number, compound 4's estimate is 13-fold (1.11 log units) above it; measured number outside the range, below it.
By their numbers in this assay, from the lowest: compound 2; then compound 4; then compound 1; then compound 3.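

Lengthening at this position, on a saturated chain carbon eight bonds along the chain from a carbonyl carbon, still moves the result in this assay: nonyl in place of hydrogen brings a 9.7-fold lower number from compound 3 to compound 4 (0.99 log units; beyond the scatter) as a modest step. The earlier change of 1-methylbutyl to octyl gave a 1300-fold higher number from compound 2 to compound 3 (3.10 log units; beyond the scatter) in the opposite direction, so among the compounds shown a longer chain on the carbonyl carbon does not push the number one way, and compound 4 goes against any rising trend. Nothing shown accounts for this turn.

From the compounds shown here alone, whether a longer chain still would lower the number further, or where between the octyl chain of compound 3 and the chain of compound 4 the turn lies, stays open. Also open, going by these compounds, is what an amine or a carboxylic acid at the end of this chain would do.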